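Piperazine nitrogen swap on the shared core

The compounds below may be only part of what the source reports. "The series", "measured", "known", "first", "only" and "open" are said of these compounds alone.

Two compounds of the series have been run in a functional assay on MDA-MB-231 cells (Homo sapiens) for inhibition, read by sulforhodamine B assay; a higher number here means a weaker inhibitor, a lower number a stronger inhibitor. Compound 1 `COC(=O)CC/C(C)=C/Cc1c(OC)c(C)c2c(c1OCC#CCN1CCN(C(=O)C3COc4ccccc4O3)CC1)C(=O)OC2` returns only a limit of the assay: in this assay compound 1 gives > 50000 nM. Compound 2 `COC(=O)CC/C(C)=C/Cc1c(OC)c(C)c2c(c1OCC#CCN1CCC(Cc3ccccc3)CC1)C(=O)OC2` likewise stops at a limit, and in this assay compound 2 gives > 50000 nM. Among the compounds with values here, no measured pair differs in only one place, so no single step has been sized; what is shared is the limit of > 50000 nM in this assay, at which 2 of the 2 values shown sit, which leaves compound 1 at the edge of what this assay can report rather than at a number.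

Compound 3 `COC(=O)CC/C(C)=C/Cc1c(OC)c(C)c2c(c1OCC#CCN1CCN(c3ccccc3F)CC1)C(=O)OC2` is the next candidate. Relative to compound 1 it carries 2-fluorophenyl in place of (2,3-dihydro-1,4-benzodioxin-2-yl)carbonyl on an amine nitrogen in a ring. With both known values sitting at a limit, the data give no direction for this change; an expected step of a number no higher from compound 1 to compound 3 (the limit leaves the size open) from compound 1 to compound 3 is written only as a placeholder, not as a trend beyond the scatter. Compound 3 is expected to give 50000 nM in this assay, within 15000 nM to 100000 nM, with a substantial chance that again only a limit is reported.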

Compound 3, half-maximal inhibitory concentration: > 50000 nM
Compound 3 gave a limit, no number; the forecaster's own chance of this, stated with the estimate: 70%; the middle value sits exactly at the limit.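

The change from compound 1 to compound 3 gives no readable step in this assay, and compounds 1 and 3 both remain limits: the limit of > 50000 nM in this assay, at which 3 of the 3 values shown sit.

The compounds shown leave open whether any group on that ring nitrogen of the shared core gives a number rather than a limit, and how large such a step would be.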